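The source may hold more compounds than are shown below. What is called first, only, known or untested is meant among the compounds shown, and "the series" means these compounds.

Series notes, shared core varying the ether substituent. Compound 3 `FCCCOc1cccc(-c2cn([C@H]3CN4CCC3CC4)nn2)c1` gives 9010 nM in an assay on HEK293 cells for displacement of a labelled ligand from Neuronal acetylcholine receptor; alpha4/beta2 (Homo sapiens), read by scintillation counting, with a stated time of 120 min; a lower number here means a stronger inhibitor, a higher number a weaker inhibitor. Within the three numbers so far it holds the highest value; compound 2 `FCCOc1cccc(-c2cn([C@H]3CN4CCC3CC4)nn2)c1` gives 7050 nM, and the step of a 1.3-fold higher number from compound 2 to compound 3 (0.11 log units; within the scatter) shows that the two are indistinguishable. Compound 1 `Fc1ccc(COc2cccc(-c3cn(C4CN5CCC4CC5)nn3)c2)cc1`, which carries the (4-fluorobenzyl)oxy group with no configuration specified at the saturated carbon of the bicyclic amine, gives 1010 nM; this is the lowest number of the three, and the gap from compound 3 to compound 1 is beyond the scatter.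

Compound 4 `Fc1ccc(COc2cccc(-c3cn([C@H]4CN5CCC4CC5)nn3)c2)cc1` is the next step from compound 3: 4-fluorophenyl in place of 2-fluoroethyl on a saturated chain carbon bound to an oxygen on an aromatic ring. Among the measured compounds shown here, no measured step covers this exact exchange; the only one that touches the same chain, from compound 2 to compound 3, is small and tells nothing about a ring entering. What bears on it is compound 1, which differs from compound 4 only in that its configuration is left open. Compound 1 gives 1010 nM. A drop in the number is therefore expected, a 14-fold lower number from compound 3 to compound 4 (1.14 log units; beyond the scatter), in compound 4 as in compound 1. Compound 4 is estimated at 650 nM, in the range 250 nM to 2200 nM.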

Compound 4, inhibition constant: 6390 nM
For compound 4 the middle estimate is 9.8-fold (0.99 log units) below the measured one, and the stated range ends below it.
By their numbers in this assay, from the lowest: compound 1; then compounds 4, 2 and 3 (each within the scatter of the next).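

In this assay the size of the ether substituent, taken alone, does not separate these compounds with the configuration drawn: the steps are a 1.4-fold lower number from compound 3 to compound 4 (0.15 log units; within the scatter) and a 1.1-fold lower number from compound 2 to compound 4 (0.04 log units; within the scatter). A six-membered aromatic ring entering on a saturated chain carbon bound to an oxygen on an aromatic ring thus leaves compound 4 level with compound 2 and compound 3, and the low number of compound 1 cannot be credited to the 4-fluorophenyl group by itself. The step of a 6.3-fold higher number from compound 1 to compound 4 (0.80 log units; beyond the scatter) involves the same atoms and bonds, so the only structural feature that goes with this gap is the drawing of the stereocentre at the saturated ring carbon: the fact that one of compounds 1 and 4 is drawn with a defined configuration and the other without, at the place where they differ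

From the compounds shown here alone, what compound 1 holds at that stereocentre stays open, as does how a compound drawn with the opposite configuration, carrying the same (4-fluorobenzyl)oxy group, would read. Also open, going by these compounds, is whether an amine in place of 4-fluorophenyl, or a longer chain in place of 3-fluoropropyl, would separate from compound 4 in this assay.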